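A few compounds are considered here, and "the series" means these few. Any claim that something is new, unique, unknown or untested is made for them only; others in the source may bear on it.

Measured in an assay on isolated protein for inhibition of protein kinase C theta type (Homo sapiens), read by TR-FRET, with a stated time of 2 h; a higher number here means a weaker inhibitor, a lower number a stronger inhibitor:
compound 1 `N#Cc1cnc(NCc2cnccc2C(F)(F)F)cc1NC[C@H]1C[C@H](O)C1`: 700 nM
compound 2 `N#Cc1cnc(NCc2cncnc2C(F)(F)F)cc1N[C@H]1CC[C@@H](O)CC1`: 450 nM
compound 3 `CC1(C)C[C@H](Nc2cc(NCc3cnccc3C(F)(F)F)ncc2C#N)CC(C)(C)[C@@H]1O`: 12 nM

Compound 1 carries the highest number of the three. Compound 2 lies within the scatter of compound 1, so nothing separates them; compound 3 stands far lower, beyond the scatter. Compound 4 `CC1(C)C[C@@H](Nc2cc(NCc3cnccc3C(F)(F)F)ncc2C#N)CC[C@@H]1O` differs from compound 1 at one place: 4-hydroxy-3,3-dimethylcyclohexyl in place of (3-hydroxycyclobutyl)methyl on a nitrogen on an aromatic ring. The 4-hydroxy-3,3-dimethylcyclohexyl group entering compound 4 resembles the ring on compound 3 more closely than the (3-hydroxycyclobutyl)methyl group it replaces, and compound 3 gives 12 nM in this assay. A downward step beyond the scatter is therefore expected, a 16-fold lower number from compound 1 to compound 4 (1.19 log units; beyond the scatter), though not the whole way to compound 3. Compound 4 is estimated at 45 nM, with a likely range of 12 nM to 170 nM.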

Compound 4, half-maximal inhibitory concentration: 120 nM
Compound 4: the middle estimate sits 2.7-fold (0.43 log units) below what was measured; low and high end bracket the measured number.
By their numbers in this assay, from the lowest: compound 3; then compound 4; then compounds 2 and 1 (each within the scatter of the next).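

Among the compounds shown here, on the nitrogen on an aromatic ring, 4-hydroxy-3,3-dimethylcyclohexyl in place of (3-hydroxycyclobutyl)methyl gives a 5.8-fold lower number from compound 1 to compound 4 (0.77 log units; beyond the scatter) in this assay and is the first single-place comparison at this position. The group on this nitrogen therefore moves the number beyond the scatter, yet compound 4 at 120 nM still stands above compound 3 at 12 nM. No evidence at hand accounts for this step.

Going by these compounds, whether the hydroxyl itself matters remains open. An amine or a methoxy group on the same cyclohexyl ring would address that.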